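The compounds below may be only part of what the source reports. "The series", "measured", "known", "first", "only" and "open" are said of these compounds alone.

Compound 1 `CCCc1c(OC)nc2nc(C(=O)c3ccccc3)cn2c1CC` and compound 2 `CCCc1c(SC)nc2nc(C(=O)c3ccccc3)cn2c1CC` share one core and differ only at one aromatic carbon. In a functional assay on the whole organism with Rattus norvegicus as the target (a higher number here means that more compound is needed for the effect, a lower number that less compound is needed), compound 1 gives 10 mg/kg, and compound 2 gives 10 mg/kg; the step of no change at the digits printed from compound 1 to compound 2 (within the scatter) leaves the two level at the digits recorded. Among the measured compounds shown here, compound 1 therefore stands level with its only measured neighbour, and nothing so far shows a shift beyond the scatter.

Compound 3 `CCc1cc(OC)nc2nc(C(=O)c3ccccc3)cn12` is not yet measured. It differs from compound 1 as follows: hydrogen in place of propyl on an aromatic carbon. For the measured compounds named here, no measured step touches that position or removes a chain in this way, so none bears directly on the change; the single known step concerns another site and was flat. With no directional evidence, the expected step of a 1.5-fold higher number from compound 1 to compound 3 (0.18 log units; within the scatter) is taken as none beyond the scatter. For compound 3 the estimate in this assay is 15 mg/kg, with a range from 5 mg/kg to 45 mg/kg.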

Compound 3, minimum effective dose: 2 mg/kg
Estimate against measurement, compound 3: 7.5-fold (0.88 log units) above; the whole stated range lies above it.
By their numbers in this assay, from the lowest: compound 3; then compounds 1 and 2 (each within the scatter of the next).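

In this assay, hydrogen in place of propyl on this aromatic carbon gives a 5.0-fold lower number from compound 1 to compound 3 (0.70 log units; beyond the scatter). Among the compounds shown here, this is the first step beyond the scatter, whereas the exchange of methoxy for methylsulfanyl at another aromatic carbon left the values level, so this position does respond to its substituent, and losing the propyl chain lowers the dose needed instead of raising it. Nothing at hand accounts for this shift.

Propyl and hydrogen are the only two substituents shown here, so it remains open whether a methyl group would fall between them or whether a longer chain such as butyl would raise the number further. Also open, as far as these compounds go, is whether methylsulfanyl in place of methoxy stays without effect when hydrogen occupies this position.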